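The compounds below may be only part of what the source reports. "The series", "measured", "known", "first", "only" and "open" are said of these compounds alone.

Compound 1 `Cc1nc2c(c(-c3cc(F)c4c(c3C)CCCO4)c1[C@H](OC(C)(C)C)C(=O)O)CN(CC1CC1c1ccccc1)CC2` is the point of departure. In an ADME assay on MT2 cells (Homo sapiens) for cytotoxicity, read by XTT assay, with a stated time of 4 days (on this read-out lower numbers stand for higher toxicity in this test and higher numbers for lower toxicity in this test), compound 1 gives > 40000 nM, which is a limit of the assay rather than a measured number. Two further compounds share its reading. Compound 2 `CCCCCN1CCc2nc(C)c(C(OC(C)(C)C)C(=O)O)c(-c3ccc(C)cc3)c2C1` gives in this assay > 40000 nM, again a limit. Compound 3 `Cc1ccc(-c2c3c(nc(C)c2C(OC(C)(C)C)C(=O)O)CCN(Cc2ccccc2-c2ccccc2)C3)cc1` gives in this assay > 40000 nM, also a limit. For the measured compounds named here, the only step between measured compounds that differ in one place, a step that the two limits leave unreadable from compound 2 to compound 3, therefore cannot be read, and the limit of > 40000 nM in this assay, at which 3 of the 3 values shown sit, sums up all that the three values show: every one of them sits at the same limit.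

Compound 4 `Cc1ccccc1CCCN1CCc2nc(C)c([C@H](OC(C)(C)C)C(=O)O)c(-c3cc(F)c4c(c3C)CCCO4)c2C1` is the compound still to be measured. It differs from compound 1 in one place: 2-(2-methylphenyl)ethyl in place of 2-phenylcyclopropyl on a saturated chain carbon bound to an amine nitrogen in a ring. Going by the values given here, no measured step speaks to this change, since the one step that exists is unreadable. Among the compounds with values here, what is known is only that compound 1, compound 2 and compound 3 all sit at the limit, as the limit of > 40000 nM in this assay, at which 3 of the 3 values shown sit, records. On that basis the step that the limit leaves unreadable from compound 1 to compound 4 is expected to stay within the scatter, in neither direction. Compound 4 is accordingly estimated to give 60000 nM in this assay, within the range 30000 nM to 150000 nM, most likely reported again as a limit.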

Compound 4, half-maximal cytotoxic concentration: > 40000 nM
Compound 4: a limit, no number (the forecaster's own chance of this, stated with the estimate: 85%); the middle value is on the limit's open side.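

The step between compound 1 and compound 4 cannot be read, and no other new step can be read either: the limit of > 40000 nM in this assay, at which 4 of the 4 values shown sit.

The compounds shown leave open what half-maximal cytotoxic concentration any of them would have in this assay as an actual number, and how 2-phenylcyclopropyl and 2-(2-methylphenyl)ethyl would compare once such numbers stood.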